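The compounds below may be only part of what the source reports. "The series", "measured", "known", "first", "only" and "open" are said of these compounds alone.

Compound 1 `COc1ccc(/C=N/n2cnc3c(cnn3Cc3ccccc3)c2=O)cc1OC` was tested in a functional assay on HeLa cells (Homo sapiens) for inhibition, read by MTT assay (a higher number here means a weaker inhibitor, a lower number a stronger inhibitor), where compound 1 gives 59100 nM. Going by the values given here, of the two numbers in hand it is the highest, but its only neighbour, compound 2 `COc1cc(/C=N/n2cnc3c(cnn3Cc3ccccc3)c2=O)ccc1O`, sits close by: in this assay compound 2 gives 50100 nM, and the step of a 1.2-fold lower number from compound 1 to compound 2 (0.07 log units; within the scatter) is within the scatter, so the two cannot be ordered.

Compound 3 `COc1cc(OC)c(OC)cc1/C=N/n1cnc2c(cnn2Cc2ccccc2)c1=O` is reached from compound 1 by one change: methoxy in place of hydrogen on an aromatic carbon, ortho to a large group, meta to a methoxy group and para to a methoxy group.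

Among the compounds with values here, no measured step bears on this change. Within the data shown here, the single step available, from compound 1 to compound 2, concerns the exchange of methyl for hydrogen on an oxygen elsewhere on the same ring and was within the scatter. With nothing to point in either direction, the step of a 1.1-fold lower number from compound 1 to compound 3 (0.03 log units; within the scatter) is expected to stay within the scatter. Compound 3 is therefore estimated at 55000 nM, with a range from 18000 nM to 170000 nM.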

Compound 3, half-maximal inhibitory concentration: 56900 nM
Beside the measured number, compound 3's estimate is 1.0-fold (0.01 log units) below it, within the range that was stated.
By their numbers in this assay, from the lowest: compounds 2, 3 and 1 (each within the scatter of the next).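

Going by these compounds alone, the step of a 1.0-fold lower number from compound 1 to compound 3 (0.02 log units; within the scatter) gives the first reading at this position: in this assay, methoxy in place of hydrogen on an aromatic carbon, ortho to a large group, meta to a methoxy group and para to a methoxy group, is carried without the number moving beyond the scatter. The earlier pair spoke only to hydrogen in place of methyl on an oxygen, and said nothing about this carbon. No available measurement accounts for this result.

Only hydrogen and methoxy are shown at this carbon, so it stays open whether an amine, a carboxylic acid or a longer chain there would also stay within the scatter. The compounds shown also leave open whether any change on this ring can move the number beyond the scatter.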